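The source may hold more compounds than are shown below. What is called first, only, known or untested is meant among the compounds shown, and "the series" means these compounds.

Compound 3, `CCN(Cc1ccccc1OC)C(=O)C1CCN(S(=O)(=O)c2ccc3cn[nH]c3c2)CC1`, gives 92% in a functional assay on CHO cells for positive allosteric modulation of muscarinic acetylcholine receptor M5 (Homo sapiens), read by calcium flux; a lower number here means a smaller maximal response, a higher number a larger maximal response. Compound 1, `CCN(Cc1ccccc1)C(=O)C1CCN(S(=O)(=O)c2ccc3cn[nH]c3c2)CC1`, gives 86%, and compound 2, `CCN(Cc1ccccc1F)C(=O)C1CCN(S(=O)(=O)c2ccc3cn[nH]c3c2)CC1`, gives 84%; the steps of a number 6 percentage points higher from compound 1 to compound 3 (within the scatter) and a number 8 percentage points higher from compound 2 to compound 3 (within the scatter) both fall within the scatter, so compound 3 sits among its two neighbours rather than apart from them. Compound 4, `CCN(Cc1cccc(C(F)(F)F)c1)C(=O)C1CCN(S(=O)(=O)c2ccc3cn[nH]c3c2)CC1`, differs from compound 3 by 3-(trifluoromethyl)phenyl in place of 2-methoxyphenyl on a saturated chain carbon bound to an amide-type nitrogen. Among the measured compounds shown here, none of the measured steps alters the same part of the molecule in the same way; the nearest comparison is a number 2 percentage points lower from compound 1 to compound 2 (within the scatter), a fluorine-bearing substitution that also stayed within the scatter. The step of a number 7 percentage points lower from compound 3 to compound 4 (within the scatter) is therefore expected to be small, with no clear direction. Compound 4 is estimated at 85%, with a range from 70% to 98%.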

Compound 4, largest response reached (reported as percent of maximum), in percent of the reference or control that the assay uses: 59%
Beside the measured number, compound 4's estimate is 26 percentage points above it; measured number outside the range, below it.
By their numbers in this assay, from the lowest: compound 4; then compounds 2, 1 and 3 (each within the scatter of the next).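

In this assay, the aromatic ring of the benzyl group had shown no step beyond the scatter with fluoro or methoxy, but trifluoromethyl gives a clear fall in maximal response: a number 27 percentage points lower from compound 1 to compound 4 (beyond the scatter). The steps of a number 25 percentage points lower from compound 2 to compound 4 (beyond the scatter) and a number 33 percentage points lower from compound 3 to compound 4 (beyond the scatter) are also beyond the scatter, although each replaces one substituted phenyl with another. Nothing available explains the fall.

The compounds shown do not separate the effect of trifluoromethyl from that of its place on the ring. A 3-methoxyphenyl or 2-(trifluoromethyl)phenyl compound would address this.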